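Trading the methoxy-bearing chain end of compound 3

The source may report more compounds than this note shows. Statements on the series, on what has been measured and on what is new or still open speak of the compounds shown alone.

In a physicochemical assay for lipophilicity (on this read-out lower numbers stand for lower lipophilicity and higher numbers for higher lipophilicity), compound 1 `CC(/C=C/CC(C)CCCC(C)C)=C\C(=O)OC(C)C` gives 7.15 and compound 2 `CC(/C=C/CC(C)CCCC(C)(C)OC(C)C)=C\C(=O)OC(C)C` gives 6.9, while compound 3 `COC(CCC(C)C/C=C/C(C)=C/C(=O)OC(C)C)C(C)C`, at 5.95, is the lowest of the three. Compound 4 `C=C(C)CCCC(C)C/C=C/C(C)=C/C(=O)OC(C)C` differs from it as follows: 2-methylprop-2-en-1-yl in place of 1-methoxy-2-methylpropyl on a saturated chain carbon, four bonds along the chain from a double-bonded chain carbon. In words, 2-methylprop-2-en-1-yl replaces 1-methoxy-2-methylpropyl, so the methoxy is gone. For the measured compounds named here, two measured steps bear on this change: a number 1.20 log units lower from compound 1 to compound 3 (beyond the scatter), where a methoxy came in, and a number 0.95 log units lower from compound 2 to compound 3 (beyond the scatter). The isopropoxy step, a number 0.25 log units lower from compound 1 to compound 2 (within the scatter), offers little guidance. A rise of similar, modest size is therefore expected, beyond the scatter, and in this assay the expected step is a number 0.85 log units higher from compound 3 to compound 4 (beyond the scatter). Compound 4 is estimated at 6.8, within an expected range of 6.4 to 7.2.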

Compound 4, partition coefficient: 6.6
For compound 4 the middle estimate is 0.20 log units above the measured one, within the range that was stated.
By their numbers in this assay, from the lowest: compound 3; then compounds 4, 2 and 1 (each within the scatter of the next, the first and the last beyond it).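

Replacing 1-methoxy-2-methylpropyl with 2-methylprop-2-en-1-yl gives a number 0.65 log units higher from compound 3 to compound 4 (beyond the scatter) in this assay and so wins back only part of the drop seen with compound 3. Even without oxygen, this chain end gives a number 0.55 log units lower from compound 1 to compound 4 (beyond the scatter) when 1-methylethenyl stands in place of isopropyl, so a drop here does not require an oxygen. Compared with the isopropoxy-bearing end, the result is a number 0.30 log units lower from compound 2 to compound 4 (within the scatter) and does not separate the two compounds.

As far as these compounds go, how an amine or a carboxylic acid at this chain end would read stays open. Nothing available explains any of these steps.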